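The compounds below may be only part of what the source reports. "The series", "measured", "known", "first", "only" and "open" are said of these compounds alone.

Three analogues of a shared core have numbers in an ADME assay on PC-3 cells (Homo sapiens) for cytotoxicity, read by sulforhodamine B assay, with a stated time of 48 h, tested at 10 uM; on this read-out higher numbers stand for more inhibition at the one concentration tested (going by the name of the read-out) and lower numbers for less inhibition. Compound 1 `CCCCc1cn(C(c2ccccc2)c2cc3cc(Br)ccc3nc2OC)nn1` gives 5.54%. Compound 2 `COc1nc2ccc(Br)cc2cc1C(c1ccccc1)n1cc(CCCO)nn1` gives 14.7%. Compound 3 `CCCCCc1cn(C(c2ccccc2)c2cc3cc(Br)ccc3nc2OC)nn1` gives 11.4%. The steps among them are all small: a number 9.2 percentage points higher from compound 1 to compound 2 (within the scatter), a number 5.9 percentage points higher from compound 1 to compound 3 (within the scatter) and a number 3.3 percentage points lower from compound 2 to compound 3 (within the scatter). Compound 3 thus sits second highest of the three numbers, nearest compound 2 and furthest from compound 1, with neither gap beyond the scatter.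

Compound 4 `COc1nc2ccc(Br)cc2cc1C(c1ccccc1)n1cc(-c2ccccc2C(F)(F)F)nn1` differs from compound 3 in one place: 2-(trifluoromethyl)phenyl in place of pentyl on an aromatic carbon. Among the compounds with values here, none of the measured steps bears on this change directly; each of them alters a saturated chain, whereas here pentyl gives way to 2-(trifluoromethyl)phenyl. Within the data shown here, the only guide is that every chain change so far has left this assay within the scatter, so no step beyond the scatter is anticipated in either direction, with the uncertainty widened for a group of a new kind. Compound 4 is therefore estimated at 12%, within 0% to 30%. This estimate means an expected step of a number 0.6 percentage points higher from compound 3 to compound 4 (within the scatter).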

Compound 4, a percentage reported as inhibition, at one concentration (the size of the read-out at that concentration, not a potency): 17.4%
Compound 4: the middle estimate sits 5.4 percentage points below what was measured, and the stated range covers the measured number.
By their numbers in this assay, from the lowest: compounds 1, 3, 2 and 4 (each within the scatter of the next, the first and the last beyond it).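

In this assay, this aromatic carbon of the five-membered aromatic ring with 3 nitrogen carries an aromatic ring as well as a saturated chain: 2-(trifluoromethyl)phenyl in place of pentyl gives a number 6 percentage points higher from compound 3 to compound 4 (within the scatter), and in place of 3-hydroxypropyl it gives a number 2.7 percentage points higher from compound 2 to compound 4 (within the scatter). The same group in place of butyl gives a number 11.9 percentage points higher from compound 1 to compound 4 (beyond the scatter), a modest step and the only one in the series printed as beyond the scatter. Nothing measured here offers a reason for these steps.

Still open, on these data alone, is whether plain phenyl, without the trifluoromethyl group, would give a similar number at this position. Also open, as far as these compounds go, is how an amine or a carboxylic acid at the end of the chain would compare with the hydroxy of compound 2.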